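The source may hold more compounds than are shown below. What is called first, only, known or untested is meant among the compounds shown, and "the series" means these compounds.

Compound 1 `CCC1=C(O)c2c(oc(-c3ccccc3)cc2=O)C(CC)(CC)C1=O` carries an unsubstituted phenyl on the shared core. In a functional assay on KB cells (Homo sapiens) for antiproliferative activity, read by sulforhodamine B assay, with a stated time of 3 days (a lower number here means that less compound is needed, a higher number that more compound is needed for the effect), compound 1 gives only a limit, > 236 uM, and not a number; this is the limit of > 236 uM in this assay, at which 1 of the 3 values shown sits. Two measured compounds replace a hydrogen on that ring. Compound 2 `CCC1=C(O)c2c(oc(-c3ccc(CC)cc3)cc2=O)C(CC)(CC)C1=O`, with an ethyl, gives 21.9 uM in this assay, which is an at least 10-fold lower number from compound 1 to compound 2 (1.03 log units; beyond the scatter). Compound 3 `CCC1=C(O)c2c(oc(-c3ccc(C(C)C)cc3)cc2=O)C(CC)(CC)C1=O`, with an isopropyl, gives 8.13 uM, so that an at least 29-fold lower number from compound 1 to compound 3 (1.46 log units; beyond the scatter), while the further change amounts to a 2.7-fold lower number from compound 2 to compound 3 (0.43 log units; beyond the scatter). Compound 4 `CCC1=C(O)c2c(oc(-c3ccc(CBr)cc3)cc2=O)C(CC)(CC)C1=O` is not yet measured; it differs from compound 1 by bromomethyl in place of hydrogen on an aromatic carbon. Both measured steps from compound 1 were large and in the same direction, and the bromomethyl matches the ethyl of compound 2 in counted size, so a step of similar magnitude is expected: an at least 11-fold lower number from compound 1 to compound 4 (1.07 log units; beyond the scatter) is the estimated change. The value for compound 4 in this assay is therefore expected to be 20 uM, with a likely range from 5 uM to 80 uM.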

Compound 4, concentration for half-maximal effect: > 46.5 uM
Compound 4 gave a limit, no number; the forecaster's own chance of this, stated with the estimate: 10%; middle value at least 2.3-fold (0.36 log units) from the limit.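

In this assay compound 4 gives only a limit and not a number: the limit of > 46.5 uM in this assay, at which 1 of the 4 values shown sits. Even so, the limit is enough to set bromomethyl apart from the two alkyl groups at this position, with an at least 5.7-fold higher number from compound 3 to compound 4 (0.75 log units; beyond the scatter) and an at least 2.1-fold higher number from compound 2 to compound 4 (0.32 log units; beyond the scatter). The second step is the closer comparison, as it changes only methyl to bromo on a saturated chain carbon bound to an aromatic carbon, so the earlier gain seen with ethyl and isopropyl does not hold for every group of this size here.

Going by these compounds, the step from compound 1 to compound 4 cannot be read, as both ends are limits, so whether bromomethyl lowers the number at all relative to hydrogen stays open. On these data alone, how an amine, a carboxylic acid or a longer chain such as butyl would behave at this position also remains open.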